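Methylsulfonyl for chloro on the pyridyl end of compound 2

This account rests on a few compounds, and the source may have more. Where it says the series, first, only, none or still open, it means among the compounds named here.

Measured so far:
compound 1, `O=C(CCCc1ccc([N+](=O)[O-])cn1)N1CCc2c(Cl)c(O)c(O)c(Cl)c2C1`, 74%
compound 2, `O=C(CCCc1ccc(Cl)cn1)N1CCc2c(Cl)c(O)c(O)c(Cl)c2C1`, 85%

Both compounds share the same core and differ only on an aromatic carbon of the pyridine ring. In a functional assay (Homo sapiens), tested at 1 uM (a higher number here means a weaker effect of the compound at the concentration tested, a lower number a stronger effect), compound 1 gives 74%, and compound 2 gives 85%, the higher of the two numbers; the step of a number 11 percentage points higher from compound 1 to compound 2 (beyond the scatter) is modest but beyond the scatter.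

Compound 3, `CS(=O)(=O)c1ccc(CCCC(=O)N2CCc3c(Cl)c(O)c(O)c(Cl)c3C2)nc1`, is not yet measured. It differs from compound 2 by methylsulfonyl in place of chloro on an aromatic carbon. Within the data shown here, the only measured step that bears on this change is the replacement of nitro by chloro at the same place, a number 11 percentage points higher from compound 1 to compound 2 (beyond the scatter). The reverse direction, a chloro leaving for a polar group with two hydrogen-bond acceptors entering, suggests a modest move back toward the lower number of compound 1, though a change within the scatter cannot be excluded. For compound 3 the expected result in this assay is 76%, in the range 62% to 90%, a step of a number 9 percentage points lower from compound 2 to compound 3 (within the scatter) from compound 2.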

Compound 3, a percentage reported as activity, at one concentration (the size of the read-out at that concentration, not a potency): 99%
Estimate against measurement, compound 3: 23 percentage points below; measured number outside the range, above it.
By their numbers in this assay, from the lowest: compound 1; then compound 2; then compound 3.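

In this assay, methylsulfonyl in place of chloro on this aromatic carbon, para to a large group, does not move the number toward that of the nitro compound; the step is a number 14 percentage points higher from compound 2 to compound 3 (beyond the scatter), and against nitro it is a number 25 percentage points higher from compound 1 to compound 3 (beyond the scatter). Nitro and methylsulfonyl therefore stand at opposite ends of the three compounds, with chloro between them, and compound 3 shows the weakest effect at the concentration tested, with both its steps beyond the scatter. No measurement here gives a reason for this order.

The compounds shown leave open whether an amine, a carboxylic acid or a nitrile at this place would fall below compound 1 or stay within the range already spanned. With a single concentration, they also leave open how these differences would appear as potencies.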